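Benzyl for tert-butyl: expected cytotoxicity of compound 4

A few compounds are considered here, and "the series" means these few. Any claim that something is new, unique, unknown or untested is made for them only; others in the source may bear on it.

Of the compounds shown here, three built on one shared core have so far been tested in an ADME assay on HELF cells (Homo sapiens) for cytotoxicity, with a stated time of 3 days; a lower number here means that less compound is tolerated, a higher number that more compound is tolerated. Compound 1 `CC(C)[C@H](NC(=O)[C@]1(Cc2ccccc2)CCN1C(=O)OCc1ccccc1)C(N)=O` gives > 100000 nM, which is a limit of the assay rather than a measured number. Compound 2 `NC(=O)[C@H](CCC(=O)O)NC(=O)C1(Cc2ccccc2)CCN1C(=O)OCc1ccccc1` gives > 100000 nM, again a limit. Compound 3 `C[C@H](NC(=O)[C@@]1(Cc2ccccc2)CCN1C(=O)OCc1ccccc1)C(=O)NC(C)(C)C` gives > 100000 nM, once more a limit. Compound 3 therefore stands exactly where the other two values stand, at the limit of > 100000 nM in this assay, at which 3 of the 3 values shown sit. Among the compounds with values here, since no compound in this set has a number below that limit, no step between measured compounds can be read, and nothing in the data separates one compound from another.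

Compound 4 `C[C@H](NC(=O)[C@@]1(Cc2ccccc2)CCN1C(=O)OCc1ccccc1)C(=O)NCc1ccccc1` has not yet been measured in this assay. It differs from compound 3 in a single place: benzyl in place of tert-butyl on an amide-type nitrogen. Within the data shown here, because the limit of > 100000 nM in this assay, at which 3 of the 3 values shown sit, holds for every compound so far, the expectation for the step from compound 3 to compound 4 is no change beyond the usual scatter, and the step is expected to be a number no higher from compound 3 to compound 4 (the limit leaves the size open). Compound 4 is accordingly estimated at 100000 nM, with a range from 50000 nM to 200000 nM, and is expected most likely to come back as a limit again rather than as a number.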

Compound 4, minimum cytotoxic concentration: >= 20000 nM
Compound 4: a limit, no number (the forecaster's own chance of this, stated with the estimate: 80%); the middle value lies beyond the limit too.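

Compound 3 and compound 4 each return a limit rather than a number, so the step from tert-butyl to benzyl on the amide-type nitrogen cannot be read. The compounds shown leave open whether any of them has a minimum cytotoxic concentration that can be given as a number in this assay, and whether benzyl and tert-butyl differ there at all.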